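Moving the Methylpyridine Attachment on the Sulfonyl Sulfur

The compounds below may be only part of what the source reports. "The series", "measured", "known", "first", "only" and "open" are said of these compounds alone.

Compound 1 `CNCc1cn(S(=O)(=O)c2cccc(OC)n2)c(-c2cccnc2F)c1F`: 98%
Compound 2 `CNCc1cn(S(=O)(=O)c2cccc(C)n2)c(-c2cccnc2F)c1F`: 91%

In a functional assay on the whole organism (strain Jcl:Sprague-Dawley) for inhibition, with Rattus norvegicus as the target, with stated times of 3 min and 3 h, at a dose of 1 mg/kg by the intravenous route (on this read-out higher numbers stand for more inhibition at the one dose given (going by the name of the read-out) and lower numbers for less inhibition), compound 2 gives 91%, the lowest of two numbers, yet the gap to compound 1, a number 7 percentage points lower from compound 1 to compound 2 (within the scatter), lies within the scatter. Compound 3 `CNCc1cn(S(=O)(=O)c2cccnc2C)c(-c2cccnc2F)c1F` differs from compound 2 in one place: 2-methylpyridin-3-yl in place of 6-methylpyridin-2-yl on a sulfonyl sulfur. Going by the values given here, the only measured step, a number 7 percentage points lower from compound 1 to compound 2 (within the scatter), swaps a group on the ring and not where the ring joins the sulfonyl sulfur, so it gives little guidance. Compound 3 is therefore estimated at 80%, with a range from 40% to 98%, an expected step of a number 11 percentage points lower from compound 2 to compound 3 (beyond the scatter).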

Compound 3, a percentage reported as inhibition, in the whole organism at one dose (the size of the read-out at that dose, not a potency): 92%
Beside the measured number, compound 3's estimate is 12 percentage points below it; measured number inside the range.
By their numbers in this assay, from the lowest: compounds 2, 3 and 1 (each within the scatter of the next).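

In this assay, changing the group on the sulfonyl sulfur from 6-methylpyridin-2-yl to 2-methylpyridin-3-yl gives a number 1 percentage points higher from compound 2 to compound 3 (within the scatter), so here a different attachment of the methylpyridine, and not just a swapped ring substituent, leaves the read-out within the scatter. Against the methoxy analogue the picture is the same, with a number 6 percentage points lower from compound 1 to compound 3 (within the scatter). Nothing measured here explains this result. Still open, on these data alone, is how a pyridine carrying an amine or a carboxylic acid would behave on this sulfonyl sulfur. As far as these compounds go, a plain phenyl ring there is equally open.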